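Sulfonate esters of acylated anilines: an amide becomes a urea

The source may hold more compounds than are shown below. What is called first, only, known or untested is meant among the compounds shown, and "the series" means these compounds.

Compound 1 `CC(=O)Nc1cccc(S(=O)(=O)Oc2ccccc2C(C)C)c1` gives 31000 nM in a functional assay on M21 cells (Homo sapiens) for antiproliferative activity, read by sulforhodamine B assay, with a stated time of 48 h; a higher number here means a weaker inhibitor, a lower number a stronger inhibitor.
Compound 2 `CCC(=O)Nc1ccc(S(=O)(=O)Oc2ccccc2C(C)C)cc1` gives 11000 nM in this assay.
Compound 3 `CCC(=O)Nc1ccc(S(=O)(=O)Oc2ccccc2I)cc1` gives 11000 nM in this assay.

Compound 2 stands level with compound 3 at the digits shown, the two together being the lowest numbers among the three, while compound 1 sits at a higher number that lies beyond the scatter. Within the data shown here, the one step recorded between measured compounds runs from compound 2 to compound 3, where no change at the digits printed from compound 2 to compound 3 (within the scatter) shows that swapping the group on the aromatic carbon left the number unchanged within the scatter.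

Compound 4 `CCCNC(=O)Nc1ccc(S(=O)(=O)Oc2ccccc2C(C)C)cc1` differs from compound 2 at the carbonyl carbon: propylamino in place of ethyl on a carbonyl carbon. This turns the amide of compound 2 into a urea. Among the measured compounds shown here, no measured step touches this part of the molecule; the only recorded step, from compound 2 to compound 3, concerns a different position and was flat, and compounds 1 and 2 differ in more than one place, so their values alone give no clean reading. With nothing to argue for a shift either way, the expected step of no change at the digits printed from compound 2 to compound 4 (within the scatter) is none beyond the scatter, and compound 4 is estimated at 11000 nM in this assay, within a range from 4000 nM to 30000 nM.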

Compound 4, half-maximal inhibitory concentration: 5100 nM
Beside the measured number, compound 4's estimate is 2.2-fold (0.33 log units) above it; low and high end bracket the measured number.
By their numbers in this assay, from the lowest: compound 4; then compounds 2 and 3 (each within the scatter of the next); then compound 1.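

Replacing ethyl with propylamino on the carbonyl carbon turns the amide into a urea and gives a 2.2-fold lower number from compound 2 to compound 4 (0.33 log units; beyond the scatter) in this assay, the first sign that this position can move the number, even if only modestly. Among these compounds, the only earlier step between compounds differing in one place, no change at the digits printed from compound 2 to compound 3 (within the scatter), concerned a different group and stayed flat. This new step brings in a nitrogen and a longer chain together, so it cannot separate what each contributes, and nothing available here explains the shift.

Still open, on these data alone, is how the number responds to other groups on the same carbonyl carbon, such as a shorter methylamino, a longer butylamino or a propoxy group, which has an oxygen where the urea has its nitrogen. Also open, as far as these compounds go, is whether iodo in place of isopropyl on an aromatic carbon would stay as flat on the urea as it did on the amide, or whether the urea and that swap would combine to give a different number.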